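Replacing the thienyl hydrazone with a 4-nitrophenyl hydrazone

This account rests on a few compounds, and the source may have more. Where it says the series, first, only, none or still open, it means among the compounds named here.

Measured compounds:
compound 1, `CCCSc1nc(N/N=C(\C)c2ccc(O)cc2)c2nnn(Cc3ccccc3)c2n1`, 16700 nM
compound 2, `CCCSc1nc(N/N=C/c2cccs2)c2nnn(Cc3ccccc3)c2n1`, > 64000 nM

Going by the values given here, compound 1 is the only compound of the pair with a numeric reading in a functional assay on MGC-803 cells (Homo sapiens) for antiproliferative activity, read by MTT assay, with a stated time of 72 h; on this read-out lower numbers stand for stronger inhibition and higher numbers for weaker inhibition. For compound 2 the reading is a limit of this assay, (the limit of > 64000 nM in this assay, at which 1 of the 2 values shown sits), so compound 2 stands at the weaker edge of what this assay reports. Among the compounds with values here, the single measured step bears on the planned change only by analogy: an at least 3.8-fold higher number from compound 1 to compound 2 (0.58 log units; beyond the scatter), where a six-membered aryl hydrazone was traded for a five-membered one.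

Compound 3, `CCCSc1nc(N/N=C/c2ccc([N+](=O)[O-])cc2)c2nnn(Cc3ccccc3)c2n1`, reverses that ring-size change: 4-nitrophenyl in place of thiophen-2-yl on a carbon with a double bond to nitrogen. On these data alone, since the move to the five-membered ring cost potency, returning to a six-membered ring is expected to recover some of it, though from a limit the starting number itself is unknown, so the expected step, an at least 2.1-fold lower number from compound 2 to compound 3 (0.32 log units; beyond the scatter), is a loose one. Compound 3 is therefore estimated at 30000 nM in this assay, between 8000 nM and 64000 nM.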

Compound 3, half-maximal inhibitory concentration: 10100 nM
Estimate against measurement, compound 3: 3.0-fold (0.47 log units) above; the range from low to high includes it.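

In this assay, 4-nitrophenyl in place of thiophen-2-yl on a carbon with a double bond to nitrogen gives an at least 6.3-fold lower number from compound 2 to compound 3 (0.80 log units; beyond the scatter), so a change at this position alone can bring a compound from the limit of the read-out to a numeric reading. The true size of this step stays unknown, because compound 2 is only a limit: the limit of > 64000 nM in this assay, at which 1 of the 3 values shown sits. Among the compounds shown, both of those with a six-membered aromatic ring of carbon only at this place give numbers, and the one with the five-membered ring does not.

On these data alone, what remains open is whether the gain belongs to the ring or to its nitro group, which a plain phenyl or a 4-aminophenyl on this carbon could separate. As far as these compounds go, the rest of the core is the same in all three compounds, so it is also open whether the step would hold with a longer chain elsewhere on it.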